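A few compounds are considered here, and "the series" means these few. Any claim that something is new, unique, unknown or untested is made for them only; others in the source may bear on it.

Values in an ADME assay on L02 cells (Homo sapiens) for cytotoxicity, read by MTT assay, with a stated time of 24 h; on this read-out higher numbers stand for weaker inhibition and lower numbers for stronger inhibition:
- compound 1 `COc1cc(/C=C2\CN(C)C/C(=C\c3ccc(F)cc3)C2=O)cc(OC)c1`: 21900 nM
- compound 2 `COc1cc(/C=C2\CN(C)C/C(=C\c3ccc(Cl)cc3Cl)C2=O)cc(OC)c1`: 18800 nM
- compound 3 `COc1cc(/C=C2\CN(C)C/C(=C\c3ccc(F)cc3)C2=O)cc(OC)c1OC`: 10700 nM

Compound 3 at 10700 nM lies within the scatter of compound 2 at 18800 nM. The only listed step beyond the scatter is modest: a 2.0-fold lower number from compound 1 to compound 3 (0.31 log units; beyond the scatter). The next compound, compound 4 `COc1cc(/C=C2\CN(C)C/C(=C\c3ccc(C#N)cc3)C2=O)cc(OC)c1OC`, has cyano in place of fluoro on an aromatic carbon, turning 4-fluorophenyl into 4-cyanophenyl: cyano in place of fluoro on an aromatic carbon.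

Within the data shown here, two measured steps bear on this change, and neither is a direct precedent. The closer one replaces the same 4-fluorophenyl group with 2,4-dichlorophenyl and gives a 1.2-fold lower number from compound 1 to compound 2 (0.07 log units; within the scatter), so that swap moved this assay no further than the scatter. The methoxy step, a 2.0-fold lower number from compound 1 to compound 3 (0.31 log units; beyond the scatter), leaves the 4-fluorophenyl group untouched and serves only as a guide to how far a single change has moved the number in this series. Among the measured compounds shown here, no cyano compound has been measured, so the direction stays open and a wide range is warranted. The expected result is no shift beyond the scatter, with the estimated step being a 1.1-fold lower number from compound 3 to compound 4 (0.03 log units; within the scatter). For compound 4 the estimated value is 10000 nM, with an expected range from 4000 nM to 24000 nM.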

Compound 4, half-maximal inhibitory concentration: 18600 nM
The estimate for compound 4 lay 1.9-fold (0.27 log units) below the measured number; low and high end bracket the measured number.
By their numbers in this assay, from the lowest: compounds 3, 4, 2 and 1 (each within the scatter of the next, the first and the last beyond it).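

Within this assay, cyano in place of fluoro on an aromatic carbon, para to a large group, gives a 1.7-fold higher number from compound 3 to compound 4 (0.24 log units; within the scatter), so turning 4-fluorophenyl into 4-cyanophenyl on the core of compound 3 does not separate the two compounds beyond the usual scatter. This is the first change at this exact aromatic carbon that keeps a single substituent there, and it extends the earlier reading from a 1.2-fold lower number from compound 1 to compound 2 (0.07 log units; within the scatter), which also stayed within the scatter: among the compounds shown, neither change to this aryl group moves the number beyond the scatter, and none goes against that. No measurement shown gives a reason for this flat response, and the result alone cannot supply one.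

As far as these compounds go, what an amine or a carboxylic acid on this aromatic carbon would do to the number remains open, since fluoro and cyano cover only a narrow part of what could sit there. Also open, from the compounds shown here alone, is whether the cyano step would read the same on the core of compound 1, which lacks the methoxy that separates it from compound 3.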